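A Phenyl for an Ethyl on the Triazole Nitrogen

A few compounds are considered here, and "the series" means these few. Any claim that something is new, unique, unknown or untested is made for them only; others in the source may bear on it.

Of the compounds shown here, three have been tested in a functional assay on the whole organism (strain albino) for inhibition, with Rattus norvegicus as the target, read by paw edema, with stated times of 30 min and 1 h, at a dose of 0.28 mmol/kg by the oral route; a lower number here means less inhibition, a higher number more inhibition at the dose given (going by the name of the read-out). Compound 1, with structure `C/C(=N\O)c1ccc(NC(=O)CSc2nnc(-c3ccccc3)n2-c2ccccc2)cc1`, gives 50%. Compound 2, with structure `COc1ccc(-c2nnc(SCC(=O)Nc3ccc(C(C)=O)cc3)n2-c2ccccc2)cc1`, gives 29%. Compound 3, with structure `CCn1c(SCC(=O)Nc2ccc(C(C)=O)cc2)nnc1-c1ccccc1`, gives 50%. On these numbers compound 3 stands level with compound 1 at the digits printed, and together they are the highest of the three; its nearest neighbour is compound 1, with no change at the digits printed and within the scatter, while its furthest is compound 2, a number lower by a gap that lies beyond the scatter.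

Compound 4, with structure `CC(=O)c1ccc(NC(=O)CSc2nnc(-c3ccccc3)n2-c2ccccc2)cc1`, has not yet been measured in this assay. It differs from compound 3 by phenyl in place of ethyl on an aromatic nitrogen. Among the compounds with values here, no step between measured compounds isolates this change, so the expectation rests on the whole set: compound 1 and compound 2 both carry a phenyl on an aromatic nitrogen, and in this assay compound 1 gives 50%, level with compound 3, while compound 2 gives 29%, below it.

Compound 4 is therefore expected to sit near compound 3, with a step of a number 5 percentage points lower from compound 3 to compound 4 (within the scatter) that stays within the scatter. The estimate for compound 4 is 45%, with a range from 30% to 60%.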

Compound 4, a percentage reported as inhibition, in the whole organism at one dose (the size of the read-out at that dose, not a potency): 41%
The estimate for compound 4 lay 4 percentage points above the measured number, within the range that was stated.
By their numbers in this assay, from the lowest: compound 2; then compounds 4, 1 and 3 (each within the scatter of the next).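

In this assay, phenyl in place of ethyl on the aromatic nitrogen can now be read as a single change, a number 9 percentage points lower from compound 3 to compound 4 (within the scatter), so the larger ring and the two-carbon chain are not told apart at this position. Compound 4 also isolates the methoxy group of compound 2: with phenyl on the nitrogen in both compounds, hydrogen in place of methoxy on an aromatic carbon gives a number 12 percentage points higher from compound 2 to compound 4 (beyond the scatter), a modest step, and so the low number of compound 2 goes with the methoxy and not with the phenyl on the nitrogen. The group of 3 heavy atoms in place of the group of 4 heavy atoms on an aromatic carbon gives a number 9 percentage points lower from compound 1 to compound 4 (within the scatter), and no measurement in hand explains any of these three steps.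

As far as these compounds go, whether a propyl chain or a benzyl group on the aromatic nitrogen would read apart from ethyl and phenyl remains open. So does whether methoxy would go with the same lower number when ethyl rather than phenyl sits on that nitrogen, and a single dose says nothing of potency in either case.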